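This account rests on a few compounds, and the source may have more. Where it says the series, first, only, none or still open, it means among the compounds named here.

Measured so far in a functional assay on HCT-116 cells (Homo sapiens) for antiproliferative activity, read by MTT assay, with a stated time of 72 h; on this read-out lower numbers stand for stronger inhibition and higher numbers for weaker inhibition:
- compound 1 `COc1ncc(-c2ccc3c(c2)N(c2ccc(F)cc2)C(=O)CO3)cc1NS(=O)(=O)c1ccc(F)cc1`: > 40000 nM
- compound 2 `COc1cccc(N2C(=O)COc3ccc(-c4cnc5ccccc5c4)cc32)c1`: 8240 nM
- compound 3 `COc1cccc(N2C(=O)COc3ccc(-c4cccc(NS(=O)(=O)c5ccc(F)cc5)c4)cc32)c1`: > 40000 nM

Compound 1 stands at > 40000 nM, which is a limit and not a number. Compound 3 stands at > 40000 nM, also a limit. Together they give (the limit of > 40000 nM in this assay, at which 2 of the 3 values shown sit). Going by the values given here, compound 2, at 8240 nM, is the only compound with a number.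

Compound 4 `O=C1COc2ccc(-c3cnc4ccccc4c3)cc2N1c1ccccc1` has hydrogen in place of methoxy on an aromatic carbon of compound 2, turning 3-methoxyphenyl to phenyl: hydrogen in place of methoxy on an aromatic carbon. Among the compounds with values here, no measured pair isolates this change, so no step beyond the scatter is expected in this assay, in either direction. The expected move is a 1.0-fold lower number from compound 2 to compound 4 (0.01 log units; within the scatter). Compound 4 is estimated at 8000 nM, with an expected range from 2500 nM to 25000 nM.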

Compound 4, half-maximal inhibitory concentration: > 40000 nM
Compound 4 ended at the assay's limit (the forecaster's own chance of this, stated with the estimate: 10%); middle value at least 5.0-fold (0.69 log units) from the limit.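

In this assay, going by these compounds alone, the change from 3-methoxyphenyl to phenyl gives an at least 4.8-fold higher number from compound 2 to compound 4 (0.68 log units; beyond the scatter), the first step that isolates a single place. Compound 4 gives > 40000 nM, a limit, so the full size of this step cannot be read. With the methoxy gone, compound 2 remains the only compound with a number, and the rest sit at the assay's ceiling: the limit of > 40000 nM in this assay, at which 3 of the 4 values shown sit.

From the compounds shown here alone, whether the methoxy is specifically required at this place remains open; a hydroxyl, an amine or an ethoxy on the same carbon would test this. Also open, going by these compounds, is whether methoxy on another carbon of this ring would serve equally.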